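A dimethylamino group replaces vinyl in compound 4

This account rests on a few compounds, and the source may have more. Where it says the series, first, only, none or still open, it means among the compounds named here.

In a functional assay (trachea) with Cavia porcellus as the target (a lower number here means that less compound is needed, a higher number that more compound is needed for the effect), compound 1 `CCCn1c(=O)n(CC)c(=O)c2[nH]cnc21` gives 1300 nM and compound 2 `CCCn1c(=O)n(CCCO)c(=O)c2[nH]cnc21` gives 5100 nM while compound 3 `C=CCCn1cnc2c1c(=O)n(C)c(=O)n2CCC` stands highest of the three at 16800 nM on this scale. Compound 4 `CCCn1c(=O)n(C)c(=O)c2c1ncn2CCN(C)C` carries dimethylamino in place of vinyl on a saturated chain carbon, two bonds along the chain from an aromatic nitrogen. Among the compounds with values here, only one measured step falls on that kind of carbon: hydroxymethyl in place of hydrogen gave a 3.9-fold higher number from compound 1 to compound 2 (0.59 log units; beyond the scatter) in this measurement. Within the data shown here, no measured step removes vinyl, so this guide is weak. A modest move is expected, with an estimated 2.4-fold higher number from compound 3 to compound 4 (0.38 log units; beyond the scatter) in the same direction. For compound 4 the estimate is 40000 nM (expected range 10000 nM to 150000 nM).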

Compound 4, half-maximal effective concentration: > 100000 nM
Compound 4 ended at the assay's limit; the forecaster's own chance of this, stated with the estimate: 20%; at least 2.5-fold (0.39 log units) between middle value and limit.
By their numbers in this assay, from the lowest: compound 1; then compound 2; then compound 3. At a limit, above all of these: compound 4.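

Replacing but-3-en-1-yl with 2-(dimethylamino)ethyl in this assay gives an at least 5.9-fold higher number from compound 3 to compound 4 (0.77 log units; beyond the scatter). Within the data shown here, compound 3 already had the highest measured number, and this change on a saturated chain carbon, two bonds along the chain from an aromatic nitrogen, raises it further, the same direction as the one earlier step at such a carbon. The result for compound 4 is a limit of the assay, not a number: the limit of > 100000 nM in this assay, at which 1 of the 4 values shown sits.

As far as these compounds go, the true size of this step therefore stays unknown. Also open, from the compounds shown here alone, is how a primary amine or a carboxylic acid at the end of this chain would read.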